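The source may hold more compounds than are shown below. What is called first, only, known or untested is meant among the compounds shown, and "the series" means these compounds.

Four compounds are compared in an ADME assay on Vero cells (Chlorocebus sabaeus) for cytotoxicity, with a stated time of 72 h; on this read-out lower numbers stand for stronger inhibition and higher numbers for weaker inhibition. Compound 1 `O=[N+]([O-])c1cn2c(n1)OC[C@@H](OCc1cc(-c3ccc(C(F)(F)F)cc3)no1)C2` is the starting point, and in this assay compound 1 gives > 128000 nM, which is a limit of the measurement rather than a number. Compound 2 `O=[N+]([O-])c1cn2c(n1)OC[C@@H](OCc1cc(-c3ccc(F)cc3)no1)C2` differs from compound 1 by fluoro in place of trifluoromethyl on an aromatic carbon. In this assay compound 2 gives > 128000 nM, again a limit. The step that the two limits leave unreadable from compound 1 to compound 2 reflects (the limit of > 128000 nM in this assay, at which 3 of the 3 values shown sit). Compound 3 `O=[N+]([O-])c1cn2c(n1)OC[C@@H](OCc1cnn(-c3ccc(C(F)(F)F)cc3)n1)C2` rests on another core; the difference between the two cores is not broken down here. In this assay compound 3 gives > 128000 nM, once more a limit. Compound 4 `O=[N+]([O-])c1cn2c(n1)OC[C@@H](OCc1cnn(-c3ccc(F)cc3)n1)C2` differs from compound 3 by fluoro in place of trifluoromethyl on an aromatic carbon, the same change that was made from compound 1 to compound 2. Compound 4 is expected to stand at 150000 nM. The expected step that the limit leaves unreadable from compound 3 to compound 4 is flat because of the limit of > 128000 nM in this assay, at which 3 of the 3 values shown sit, so a limit is again expected.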

Compound 4, half-maximal inhibitory concentration: > 128000 nM
Compound 4 was reported as a limit (the forecaster's own chance of this, stated with the estimate: 90%); the middle value lies beyond the limit too.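

No step can be read from compound 3 to compound 4, because both values are limits rather than numbers: the limit of > 128000 nM in this assay, at which 4 of the 4 values shown sit.

The compounds shown leave open whether fluoro or trifluoromethyl, or either core, makes any difference in this assay.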